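Working notes: from compound 3 to compound 4

This account rests on a few compounds, and the source may have more. Where it says the series, first, only, none or still open, it means among the compounds named here.

Measured so far:
compound 1 `Nc1ccccc1NC(=O)c1ccc(CSC(=S)N2CCN(c3ccc(Cl)cc3)CC2)cc1` — 29%
compound 2 `CN(C(=S)SCc1ccc(C(=O)Nc2ccccc2N)cc1)c1cccnc1` — 87.7%
compound 3 `Nc1ccccc1NC(=O)c1ccc(CSC(=S)N2CCN(Cc3ccncc3)CC2)cc1` — 89.5%

All three were read in a functional assay on A-375 cells (Homo sapiens) for antiproliferative activity, read by CCK-8 assay, with a stated time of 72 h, tested at 8 uM; a higher number here means a stronger effect of the compound at the concentration tested, a lower number a weaker effect. Compound 3 stands highest of the three numbers. Its nearest neighbour is compound 2, which gives 87.7%, within the scatter of compound 3, so no order between the two can be claimed. For the measured compounds named here, compound 1 lies far below: the step of a number 60.5 percentage points higher from compound 1 to compound 3 (beyond the scatter) is large and beyond the scatter, and it is the only single-point change measured at the amine nitrogen in the ring.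

Compound 4 `CN1CCN(C(=S)SCc2ccc(C(=O)Nc3ccccc3N)cc2)CC1` is the next candidate. It differs from compound 3 as follows: hydrogen in place of pyridin-4-yl on a saturated chain carbon bound to an amine nitrogen in a ring.

Going by the values given here, no measured step covers hydrogen, or methyl, at this place. Among the compounds with values here, the one bearing step, a number 60.5 percentage points higher from compound 1 to compound 3 (beyond the scatter), shows that what sits on this nitrogen can swing the read-out widely, so the result of removing the pyridin-4-yl is open. Because compound 3 gives 89.5% and compound 1 only 29%, a downward step of moderate size is expected, a number 24.5 percentage points lower from compound 3 to compound 4 (beyond the scatter), with a wide range. Compound 4 is therefore estimated at 65%, between 30% and 90%.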

Compound 4, a percentage reported as inhibition, at one concentration (the size of the read-out at that concentration, not a potency): 91.6%
For compound 4 the middle estimate is 26.6 percentage points below the measured one; measured number outside the range, above it.
By their numbers in this assay, from the lowest: compound 1; then compounds 2, 3 and 4 (each within the scatter of the next).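

In this assay, cutting (pyridin-4-yl)methyl back to methyl on the amine nitrogen in a ring leaves the read-out unresolved from that of the parent, a number 2.1 percentage points higher from compound 3 to compound 4 (within the scatter), so in this pair the pyridin-4-yl is not required for a high read-out at the tested concentration. The large gain seen earlier, a number 60.5 percentage points higher from compound 1 to compound 3 (beyond the scatter), also appears with plain methyl, a number 62.6 percentage points higher from compound 1 to compound 4 (beyond the scatter), and exchanging methyl(pyridin-3-yl)amino for 4-methylpiperazin-1-yl on a thiocarbonyl carbon gives a number 3.9 percentage points higher from compound 2 to compound 4 (within the scatter), so among these compounds the low read-out stays with the 4-chlorophenyl of compound 1 alone. No supporting evidence bears on why these steps take this form.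

The compounds shown leave open whether the low read-out of compound 1 follows from the chlorine or from the phenyl ring itself, and an unsubstituted phenyl or a 4-chlorobenzyl on this nitrogen would separate the two. Compounds 2, 3 and 4 also remain unordered, as a read-out at a single concentration gives no potency and cannot show whether ethyl or a longer chain in place of methyl would matter at lower concentrations.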